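This account rests on a few compounds, and the source may have more. Where it says the series, first, only, none or still open, it means among the compounds named here.

The measured compounds, each tested in a functional assay on SK-HEP1 cells (Homo sapiens) for antiproliferative activity; a lower number here means a stronger inhibitor of growth, a higher number a weaker inhibitor of growth:

Compound 1 `O=c1cc(-c2ccccc2)oc2cc(OC/C(=N/O)c3ccc(F)cc3)ccc12` gives 2300000 nM in this assay.
Compound 2 `COc1ccc(/C(COc2ccc3c(=O)cc(-c4ccccc4)oc3c2)=N\O)cc1` gives 5600000 nM in this assay.
Compound 3 `O=c1c(-c2ccccc2)coc2cc(OC/C(=N/O)c3ccc(F)cc3)ccc12` gives 6610000 nM in this assay.

Compound 1 and compound 3 share the same atoms joined differently; the difference between the two cores is not broken down here. Compound 3 has the highest of the three numbers, though its value and that of compound 2 lie within the usual scatter of each other.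

Among the compounds with values here, the one counted change is methoxy in place of fluoro on an aromatic carbon, and it gave a 2.4-fold higher number from compound 1 to compound 2 (0.39 log units; beyond the scatter) in this assay.

Compound 4 `COc1ccc(/C(COc2ccc3c(=O)c(-c4ccccc4)coc3c2)=N\O)cc1` is not yet measured. It differs from compound 3 by methoxy in place of fluoro on an aromatic carbon, the same change at the same kind of place. Compound 4 is therefore expected to show a 2.1-fold higher number from compound 3 to compound 4 (0.33 log units; beyond the scatter) in this assay, an expectation resting on the step of a 2.4-fold higher number from compound 1 to compound 2 (0.39 log units; beyond the scatter) seen before. Compound 4 is estimated at 14000000 nM in this assay, most likely between 6000000 nM and 35000000 nM.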

Compound 4, concentration for 50% growth inhibition: 5510000 nM
Compound 4: the middle estimate sits 2.5-fold (0.40 log units) above what was measured; the whole stated range lies above it.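

On the core of compound 3, methoxy in place of fluoro gave a 1.2-fold lower number from compound 3 to compound 4 (0.08 log units; within the scatter) in this assay, so the change has no readable effect on that core. The step seen on the core of compound 1 therefore did not carry over to the core of compound 3: the same change on two cores in this assay, a 2.4-fold higher number (0.39 log units; beyond the scatter) from compound 1 to compound 2 and a 1.2-fold lower number (0.08 log units; within the scatter) from compound 3 to compound 4, 2.9-fold (0.47 log units) apart, beyond the scatter of two such steps

This shows that, in these four compounds, the outcome of the change depends on the core, but with one pair per core it does not show why or how other cores would behave. The compounds shown leave open what an amine or a carboxylic acid would do in place of fluoro or methoxy on that aromatic carbon. They also leave open whether a longer chain in place of methoxy would separate the two cores further.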